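A few compounds are considered here, and "the series" means these few. Any claim that something is new, unique, unknown or untested is made for them only; others in the source may bear on it.

In an ADME assay on MT4 cells (Homo sapiens) for cytotoxicity, read by MTT assay (on this read-out higher numbers stand for lower toxicity in this test and lower numbers for higher toxicity in this test), compound 3 `O=C1c2ccccc2C(=O)N1CCOC(=S)N(C(=O)c1cc(F)cc(F)c1)c1ccc(Cl)cc1` gives 59000 nM. Compound 2 `Cc1ccc(N(C(=O)c2ccc([N+](=O)[O-])cc2)C(=S)OCCN2C(=O)c3ccccc3C2=O)cc1` gives 58000 nM, within the scatter of compound 3. Compound 1 `O=C1c2ccccc2C(=O)N1CCOC(=S)N(C(=O)c1ccc([N+](=O)[O-])cc1)c1ccc(Cl)cc1` gives > 100000 nM, which is a limit of the assay and not a number. Compound 4 `Cc1ccc(N(C(=O)c2cc(F)cc(F)c2)C(=S)OCCN2C(=O)c3ccccc3C2=O)cc1` differs from compound 3 by a single swap, methyl in place of chloro on an aromatic carbon. The same swap has been measured once, as an at least 1.7-fold lower number from compound 1 to compound 2 (0.23 log units; that floor lies within the scatter). That step starts at compound 1, from the limit of > 100000 nM in this assay, at which 1 of the 3 values shown sits, so it shows only a floor. The other measured step, an at least 1.6-fold lower number from compound 1 to compound 3 (0.22 log units; that floor lies within the scatter), changes a different group. No step beyond the scatter is therefore expected in this assay. The expected change is a 1.2-fold lower number from compound 3 to compound 4 (0.07 log units; within the scatter). For compound 4 the estimated value is 50000 nM, with an expected range from 22000 nM to 100000 nM.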

Compound 4, half-maximal cytotoxic concentration: 54000 nM
Compound 4: the middle estimate sits 1.1-fold (0.03 log units) below what was measured; low and high end bracket the measured number.
By their numbers in this assay, from the lowest: compounds 4, 2 and 3 (each within the scatter of the next). At a limit, above all of these: compound 1.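

With both ends now real numbers, methyl in place of chloro gives a 1.1-fold lower number from compound 3 to compound 4 (0.04 log units; within the scatter), so at this position the swap stays within the scatter on the core carrying 3,5-difluorophenyl: the same change on two cores in this assay, an at least 1.7-fold lower number (0.23 log units; that floor lies within the scatter) from compound 1 to compound 2 and a 1.1-fold lower number (0.04 log units; within the scatter) from compound 3 to compound 4; the limit leaves it open whether they differ Likewise, 3,5-difluorophenyl in place of 4-nitrophenyl gives a 1.1-fold lower number from compound 2 to compound 4 (0.03 log units; within the scatter), which is a full step on the core carrying 4-methylphenyl: the same change on two cores in this assay, an at least 1.6-fold lower number (0.22 log units; that floor lies within the scatter) from compound 1 to compound 3 and a 1.1-fold lower number (0.03 log units; within the scatter) from compound 2 to compound 4; the limit leaves it open whether they differ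

From the compounds shown here alone, whether either change does more on the core of compound 1 stays open, since its value is only a limit: the limit of > 100000 nM in this assay, at which 1 of the 4 values shown sits. Also open is what an amine or a carboxylic acid would do at this position in this assay.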